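Changing the Aromatic Group on a Shared Core

This account rests on a few compounds, and the source may have more. Where it says the series, first, only, none or still open, it means among the compounds named here.

In a functional assay on HL-60 cells (Homo sapiens) for antiproliferative activity, read by MTT assay, with a stated time of 72 h (a higher number here means a weaker inhibitor, a lower number a stronger inhibitor), compound 1 (`CC(C)(C)c1ccc(OCCCON2C(N)=NC(N)=NC23CCSCC3)cc1`) gives 280 nM and compound 2 (`NC1=NC2(CCSCC2)N(OCCCOc2ccc(Br)cc2)C(N)=N1`) gives 350 nM. Going by the values given here, these are the only two numbers available, and they lie within the scatter of each other, so neither compound can be ranked above the other.

Compound 3 (`NC1=NC2(CCSCC2)N(OCCCOc2cc(Cl)c(Cl)cc2Cl)C(N)=N1`) keeps the rest of compound 2 and differs in one place: 2,4,5-trichlorophenyl in place of 4-bromophenyl on an oxygen on a saturated carbon. In words, 2,4,5-trichlorophenyl stands in place of 4-bromophenyl on an oxygen on a saturated carbon.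

Among the compounds with values here, only one measured step bears on this change: a 1.3-fold higher number from compound 1 to compound 2 (0.10 log units; within the scatter), with bromo in place of tert-butyl on an aromatic carbon. It alters a single group on the aromatic ring, and neither measured compound carries chlorine, so the evidence is indirect. Within the data shown here, with only that small step as a guide, no shift beyond the scatter is expected in either direction in this assay. The expected step is a 1.2-fold lower number from compound 2 to compound 3 (0.07 log units; within the scatter). For compound 3 the estimated value is 300 nM, with an expected range of 100 nM to 900 nM.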

Compound 3, half-maximal inhibitory concentration: 730 nM
Beside the measured number, compound 3's estimate is 2.4-fold (0.39 log units) below it, and the stated range covers the measured number.
By their numbers in this assay, from the lowest: compounds 1 and 2 (each within the scatter of the next); then compound 3.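

In this assay, the group on the oxygen now gives a step beyond the scatter: a 2.1-fold higher number from compound 2 to compound 3 (0.32 log units; beyond the scatter), with 2,4,5-trichlorophenyl in place of 4-bromophenyl. Going by these compounds alone, the only earlier step at this aromatic ring, a 1.3-fold higher number from compound 1 to compound 2 (0.10 log units; within the scatter), stayed within the scatter, so compound 3 is the first sign that the number responds to what the ring carries, though the step is modest and rests on a single pair. Nothing measured here accounts for this step, so the change can be described but not explained.

The compounds shown leave open whether a single chlorine on the ring would move the number as the three chlorines of compound 3 do, or whether the step belongs to the 2,4,5-trichloro pattern as a whole. They also leave open how this assay would read for a ring carrying an amine or a carboxylic acid, and for a longer chain between the shared core and the aromatic ring.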